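Swapping Bromine for Chlorine on a Pendant Phenyl Ring

This account rests on a few compounds, and the source may have more. Where it says the series, first, only, none or still open, it means among the compounds named here.

Measured so far:
compound 1 `Cc1cc(O)c(C(=O)/C=C/c2ccccc2)c(-c2ccccc2)c1C(=O)/C=C/c1ccccc1`: 10000 nM
compound 2 `Cc1cc(O)c(C(=O)/C=C/c2ccccc2)c(-c2ccc(Br)cc2)c1C(=O)/C=C/c1ccccc1`: 10000 nM
compound 3 `Cc1cc(O)c(C(=O)/C=C/c2ccc(F)cc2)c(-c2ccc(OCc3ccccc3)cc2)c1C(=O)/C=C/c1ccc(F)cc1`: 28000 nM

All three were tested in a functional assay on MCF7 cells (Homo sapiens) for cytotoxicity, read by MTT assay, with a stated time of 24 h; a higher number here means a weaker inhibitor, a lower number a stronger inhibitor. Compound 2 stands level with compound 1 at the digits shown, and together they give the lowest numbers of the three; compound 3 stands furthest away, with a higher number beyond the scatter. Compound 4 `Cc1cc(O)c(C(=O)/C=C/c2ccccc2)c(-c2ccc(Cl)cc2)c1C(=O)/C=C/c1ccccc1` differs from compound 2 in one place: chloro in place of bromo on an aromatic carbon. Among the measured compounds shown here, only one measured step bears on this change: no change at the digits printed from compound 1 to compound 2 (within the scatter). Because no change at the digits printed from compound 1 to compound 2 (within the scatter) lies within the scatter, exchanging that bromine for chlorine is expected to move the number little, if at all, so the expected step is no change at the digits printed from compound 2 to compound 4 (within the scatter). Compound 4 is therefore estimated at 10000 nM, within a range from 5000 nM to 22000 nM.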

Compound 4, half-maximal inhibitory concentration: 15000 nM
Estimate against measurement, compound 4: 1.5-fold (0.18 log units) below; the range from low to high includes it.
By their numbers in this assay, from the lowest: compounds 1, 2, 4 and 3 (each within the scatter of the next, the first and the last beyond it).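

In this assay, the change from 4-bromophenyl to 4-chlorophenyl gives a 1.5-fold higher number from compound 2 to compound 4 (0.18 log units; within the scatter) and so does not separate the two halogens. Chloro in place of hydrogen at the same place gives a 1.5-fold higher number from compound 1 to compound 4 (0.18 log units; within the scatter), so two different halogens on this aromatic carbon now leave the number within the scatter of the hydrogen-bearing compound 1. Nothing measured here offers an explanation for these small steps. Still open, from the compounds shown here alone, is whether an amine, a carboxylic acid or a longer chain at this place would move the number beyond the scatter.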